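The source may report more compounds than this note shows. Statements on the series, on what has been measured and on what is new or still open speak of the compounds shown alone.

Measured compounds:
compound 1, `COc1ccc(C2CC(Nc3nc4ccc(C)cc4s3)=NN2C(C)=O)cc1`, 39.4 umol/kg
compound 2, `COc1ccc(C2CC(Nc3nc4ccc([N+](=O)[O-])cc4s3)=NN2C(C)=O)cc1`, 149 umol/kg
compound 3, `CC(=O)N1N=C(Nc2nc3ccc(C)cc3s2)CC1c1ccc(Cl)cc1`, 27.5 umol/kg

These three values come from a functional assay on the whole organism (strain albino) with Mus musculus as the target, with a stated time of 0.5 h; a higher number here means that more compound is needed for the effect, a lower number that less compound is needed. Compound 1 and compound 2 share a core and differ in one place: nitro in place of methyl on an aromatic carbon. That change gave a 3.8-fold higher number from compound 1 to compound 2 (0.58 log units; beyond the scatter), a modest step. Compound 3 carries a different core than compound 1, and the difference is chloro in place of methoxy on an aromatic carbon; this gave a 1.4-fold lower number from compound 1 to compound 3 (0.16 log units; within the scatter), so the two cores cannot be told apart in this assay.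

Compound 4, `CC(=O)N1N=C(Nc2nc3ccc([N+](=O)[O-])cc3s2)CC1c1ccc(Cl)cc1`, has not been measured. It differs from compound 3 by nitro in place of methyl on an aromatic carbon, and the place where the change sits reads the same way as it does between compound 1 and compound 2, so it is the same change made on the other core. Since the cores of compound 1 and compound 3 behave alike in this assay, the step is expected to repeat: the estimate is a 3.8-fold higher number from compound 3 to compound 4 (0.58 log units; beyond the scatter), resting on a 3.8-fold higher number from compound 1 to compound 2 (0.58 log units; beyond the scatter). Compound 4 is therefore expected to give about 105 umol/kg, with a likely range from 50 umol/kg to 220 umol/kg.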

Compound 4, dose for half-maximal effect: 138 umol/kg
For compound 4 the middle estimate is 1.3-fold (0.12 log units) below the measured one; measured number inside the range.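

In this assay, nitro in place of methyl on the core of compound 3 gave a 5.0-fold higher number from compound 3 to compound 4 (0.70 log units; beyond the scatter), and this step agrees with the one seen on the core of compound 1: the same change on two cores in this assay, a 3.8-fold higher number (0.58 log units; beyond the scatter) from compound 1 to compound 2 and a 5.0-fold higher number (0.70 log units; beyond the scatter) from compound 3 to compound 4, 1.3-fold (0.12 log units) apart, within the scatter of two such steps. Chloro in place of methoxy, read on the pair carrying nitro, gave a 1.1-fold lower number from compound 2 to compound 4 (0.03 log units; within the scatter), and this also agrees with the pair carrying methyl: the same change on two cores in this assay, a 1.4-fold lower number (0.16 log units; within the scatter) from compound 1 to compound 3 and a 1.1-fold lower number (0.03 log units; within the scatter) from compound 2 to compound 4, 1.3-fold (0.12 log units) apart, within the scatter of two such steps. Across these four compounds, each change therefore carried from one core to the other with no detectable difference in size, but this rests on only two pairs per change and does not show that the steps would hold on any further core or for any other group.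

The compounds shown leave open how other groups in place of methyl or nitro, such as an amine or a carboxylic acid, would read in this series. They also leave open what a longer alkyl chain would do on the aromatic carbon that carries chloro or methoxy.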